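Swapping the urea cyclohexyl for a bridged bicyclic group

This account rests on a few compounds, and the source may have more. Where it says the series, first, only, none or still open, it means among the compounds named here.

Measured so far:
Compound 1 `COc1ccc(Cl)cc1C(=O)NCCC1CCN(S(=O)(=O)NC(=O)NC2CCCCC2)CC1` gives 25% in a functional assay on the whole organism (blood) with Rattus norvegicus as the target, with stated times of 24 h and 1 h, at a dose of 5 mg/kg by the intraperitoneal route; a lower number here means a weaker effect, a higher number a stronger effect of the compound at the dose given.
Compound 2 `O=C(NC1CCCCC1)NS(=O)(=O)N1CCC(CCNC(=O)c2cccc3c2OCCO3)CC1` gives 34% in this assay.

Compound 2 stands highest of the two numbers, though its gap to compound 1, a number 9 percentage points higher from compound 1 to compound 2 (within the scatter), lies within the scatter. Compound 3 `O=C(NC[C@@H]1C[C@@H]2CC[C@@H]1O2)NS(=O)(=O)N1CCC(CCNC(=O)c2cccc3c2OCCO3)CC1` differs from compound 2 by a group of 8 heavy atoms (7 carbon, 1 oxygen; 2 five-membered non-aromatic rings with 1 hetero atom each) in place of a group of 6 heavy atoms (6 carbon; one six-membered non-aromatic ring of carbon only), on an amide-type nitrogen. Among the compounds with values here, no measured step touches this position; the one known step concerns the aryl group on the carbonyl carbon and was small. With nothing pointing either way, compound 3 is expected to show a step of a number 3 percentage points lower from compound 2 to compound 3 (within the scatter), not beyond the scatter. Compound 3 is therefore estimated at 31%, with a range from 10% to 55%.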

Compound 3, a percentage reported as activity, at one dose (the size of the read-out at that dose, not a potency): 15%
Estimate against measurement, compound 3: 16 percentage points above, and the stated range covers the measured number.
By their numbers in this assay, from the lowest: compounds 3, 1 and 2 (each within the scatter of the next, the first and the last beyond it).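

Cyclohexyl on the amide-type nitrogen is not freely replaceable in this assay: the bridged bicyclic group gives a number 19 percentage points lower from compound 2 to compound 3 (beyond the scatter). Within the data shown here, this is the first step to go beyond the scatter, and it shows that this position, not only the aryl group on the carbonyl carbon, can change the read-out at this dose. Nothing measured here bears on the reason for the drop.

As far as these compounds go, it remains open whether the ring oxygen, the bridged ring or the defined stereochemistry goes with the lower number. A simple cyclopentyl or phenyl group on the same nitrogen would help to separate these features.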